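A Second Chloro on the Benzyl Ring of Compound 1

The compounds below may be only part of what the source reports. "The series", "measured", "known", "first", "only" and "open" are said of these compounds alone.

Measured compounds in a functional assay on MDA-MB-231 cells (Homo sapiens) for cytotoxicity, read by MTT assay, with a stated time of 72 h; on this read-out lower numbers stand for stronger inhibition and higher numbers for weaker inhibition:
compound 1, `CN(C)Cc1ccc2nc(NC(=O)N/N=C/c3cn(Cc4ccccc4Cl)c4ccccc34)sc2c1`, gives 1180 nM
compound 2, `CCN(CC)Cc1ccc2nc(NC(=O)N/N=C/c3cn(Cc4cccc(Cl)c4)c4ccccc34)sc2c1`, gives 2050 nM
compound 3, `CC1CCN(Cc2ccc3nc(NC(=O)N/N=C/c4cn(Cc5ccccc5Cl)c5ccccc45)sc3c2)CC1`, gives 1360 nM

Compound 1 has the smallest number of the three, but compound 2 and compound 3 both lie within the usual scatter of it, so the three cannot be told apart. Going by the values given here, the one single-point step among them, a 1.2-fold higher number from compound 1 to compound 3 (0.06 log units; within the scatter), concerns the amine on the benzylic carbon and not the benzyl ring.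

Compound 4, `CN(C)Cc1ccc2nc(NC(=O)N/N=C/c3cn(Cc4ccc(Cl)cc4Cl)c4ccccc34)sc2c1`, differs from compound 1 by chloro in place of hydrogen on an aromatic carbon. Among the compounds with values here, no measured step touches a chloro on that ring: compound 2 differs from compound 1 in two places at once, so its number says nothing clean about the chloro alone. Within the data shown here, with no step bearing on the change, compound 4 is expected to stay close to compound 1, giving a 1.0-fold higher number from compound 1 to compound 4 (0.01 log units; within the scatter), a change not beyond the scatter. The estimate for compound 4 is 1200 nM, with a range from 500 nM to 3000 nM.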

Compound 4, half-maximal inhibitory concentration: 1410 nM
The estimate for compound 4 lay 1.2-fold (0.07 log units) below the measured number, and the stated range covers the measured number.
By their numbers in this assay, from the lowest: compounds 1, 3, 4 and 2 (each within the scatter of the next).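

In this assay the change to the 2,4-dichlorobenzyl group gives a 1.2-fold higher number from compound 1 to compound 4 (0.08 log units; within the scatter) and so lies within the scatter. Going by these compounds alone, this is the first clean reading on the benzyl ring: chloro in place of hydrogen on this aromatic carbon, meta to a chloro group and para to a large group, leaves a number that cannot be told apart from that of compound 1. No measurement at hand gives a reason for this result.

Going by these compounds, whether a different group at this place, such as a methoxy group, an amine or a carboxylic acid, would also stay within the scatter remains open. Also open, on these data alone, is whether the second chloro would read the same with another amine on the benzylic carbon, such as the 4-methylpiperidin-1-yl group of compound 3.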